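The source may hold more compounds than are shown below. What is called first, only, known or untested is meant among the compounds shown, and "the series" means these compounds.

Measured so far in an assay on HEK293 cells for inhibition of transient receptor potential cation channel subfamily M member 8 (Homo sapiens), read by FLIPR and calcium flux; a higher number here means a weaker inhibitor, a lower number a stronger inhibitor:

- compound 1, `CC(C)N(C(=O)c1ccccc1OCc1ccccc1)[C@@H]1CCC[C@H](N)C1`: 5130 nM
- compound 2, `CCN(C(=O)c1ccccc1COc1ccccc1)[C@@H]1CCC[C@H](N)C1`: 280 nM
- compound 3, `CCN(C(=O)c1ccccc1OCC(C)C)[C@@H]1CCC[C@H](N)C1`: > 2000 nM

Compound 3 carries an isobutoxy group on the aromatic ring of the benzamide. Its value in this assay is a limit of the assay and not a number, so compound 3 can only be placed at or beyond the weak end of the three values shown; it sits at the limit of > 2000 nM in this assay, at which 1 of the 3 values shown sits. Among the measured compounds shown here, compound 2, with phenoxymethyl at the same position, gives 280 nM, and the step of an at least 7.1-fold higher number from compound 2 to compound 3 (0.85 log units; beyond the scatter) is the one measured change that bears on the present question: replacing the aromatic side group by a small alkoxy chain cost clearly.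

Compound 4, `CCN(C(=O)c1ccccc1Cc1ccccc1)[C@@H]1CCC[C@H](N)C1`, differs from compound 3 by benzyl in place of isobutoxy on an aromatic carbon, in words: benzyl in place of isobutoxy, on an aromatic carbon ortho to a large group. This reverses the direction of the measured step from compound 2 to compound 3, restoring a six-membered aromatic ring to the side chain while dropping the ether oxygen. Compound 1 also holds an aromatic side chain, though with a different amide substituent, and gives 5130 nM, so the aromatic ring alone does not guarantee potency.

The expectation for compound 4 is therefore a step of an at least 4.0-fold lower number from compound 3 to compound 4 (0.60 log units; beyond the scatter) in this assay, toward a stronger inhibitor. Compound 4 is estimated at 500 nM, with a range from 150 nM to 2500 nM.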

Compound 4, antagonist equilibrium constant: > 2000 nM
Compound 4: only a limit was reported; the forecaster's own chance of this, stated with the estimate: 15%; at least 4.0-fold (0.60 log units) between middle value and limit.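

In this assay compound 4 gives only a limit of the assay and not a number: the limit of > 2000 nM in this assay, at which 2 of the 4 values shown sit.

Phenyl in place of phenoxy on the saturated chain carbon bound to the aromatic carbon gives an at least 7.1-fold higher number from compound 2 to compound 4 (0.85 log units; beyond the scatter), so a six-membered aromatic ring in this side chain does not by itself keep the potency of compound 2, and the chain with its ether oxygen is the only one of the side groups on the ethyl amide here to give a number. The step between compound 3 and compound 4 cannot be read, so benzyl and isobutoxy cannot be ranked.

As far as these compounds go, whether a longer all-carbon chain such as phenethyl would recover the potency of compound 2 remains open. The same holds for a secondary amine in place of the ether oxygen.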